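Dropping the Methyl from a Cyclohexyl Urea

This account rests on a few compounds, and the source may have more. Where it says the series, first, only, none or still open, it means among the compounds named here.

Compound 1, `O=C(NCc1ccccc1)N(Cc1ccccn1)n1cnnc1`, gives in a functional assay on MCF7 cells (Homo sapiens) for cytotoxicity, read by MTT assay, with a stated time of 48 h (a lower number here means a stronger inhibitor, a higher number a weaker inhibitor), only a limit of the assay, > 50000 nM.
Compound 2, `O=C(Nc1ccccc1)N(Cc1ccccn1)n1cnnc1`, gives in this assay likewise a limit, > 50000 nM.
Compound 3, `CC1CCC(NC(=O)N(Cc2ccccn2)n2cnnc2)CC1`, gives in this assay 34000 nM.

Going by the values given here, compound 3 thus holds the only number among the three values; the other two sit at the limit of > 50000 nM in this assay, at which 2 of the 3 values shown sit. Compound 4, `O=C(NC1CCCCC1)N(Cc1ccccn1)n1cnnc1`, differs from compound 3 by hydrogen in place of methyl on a saturated ring carbon. Among the compounds with values here, the steps that bear on it are an at least 1.4-fold lower number from compound 1 to compound 3 (0.16 log units; that floor lies within the scatter) and an at least 1.4-fold lower number from compound 2 to compound 3 (0.16 log units; that floor lies within the scatter), both floors that remain within the scatter, and neither touches the methyl itself. Compound 4 is therefore expected to stay near compound 3, with a step of a 1.2-fold higher number from compound 3 to compound 4 (0.07 log units; within the scatter) that does not rise beyond the scatter. For compound 4 the estimate is 40000 nM, expected to lie between 15000 nM and 110000 nM.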

Compound 4, half-maximal inhibitory concentration: 46900 nM
The estimate for compound 4 lay 1.2-fold (0.07 log units) below the measured number, and the stated range covers the measured number.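

Taking the methyl off the saturated ring carbon leaves this assay without a readable change, with a 1.4-fold higher number from compound 3 to compound 4 (0.14 log units; within the scatter), so at this position hydrogen and methyl cannot be told apart. Cyclohexyl in place of the other two groups gives only floors, an at least 1.0-fold lower number from compound 2 to compound 4 (0.02 log units; that floor lies within the scatter) and an at least 1.0-fold lower number from compound 1 to compound 4 (0.02 log units; that floor lies within the scatter), and neither is a real separation. Compound 1 and compound 2 are limits of the assay and not numbers: the limit of > 50000 nM in this assay, at which 2 of the 4 values shown sit. Going by these compounds, whether a hydroxyl or an amine on this ring carbon, or a longer chain in place of the methyl, would move the number beyond the scatter stays open.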